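Replacing isopropyl with 4-methylphenyl on an inactive core

A few compounds are considered here, and "the series" means these few. Any claim that something is new, unique, unknown or untested is made for them only; others in the source may bear on it.

Compound 1, `Cc1cc(C)c(N2CCN(c3ncccn3)CC2)nn1`, in a functional assay on BV-2 cells (Mus musculus) for inhibition, read by ELISA, with a stated time of 16 h (a higher number here means a weaker inhibitor, a lower number a stronger inhibitor), gives > 100000 nM.
Compound 2, `Cc1cc(C(C)C)nnc1N1CCN(c2ncccn2)CC1`, in this assay gives > 100000 nM.

Each of these numbers is a limit of this assay, not a measured potency, so compound 2 stands only at that limit. Going by the values given here, the single change between them, a step that the two limits leave unreadable from compound 1 to compound 2, cannot be sized because both values sit at the limit of > 100000 nM in this assay, at which 2 of the 2 values shown sit. Compound 3, `Cc1ccc(-c2cc(C)c(N3CCN(c4ncccn4)CC3)nn2)cc1`, differs from compound 2 in one place: 4-methylphenyl in place of isopropyl on an aromatic carbon. No readable measured step bears on this change, so no direction beyond the scatter is expected. The expected step of a number no higher from compound 2 to compound 3 (the limit leaves the size open) is therefore estimated near zero. Compound 3 is estimated at 100000 nM, within 5000 nM to 300000 nM.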

Compound 3, half-maximal inhibitory concentration: 17200 nM
Estimate against measurement, compound 3: 5.8-fold (0.76 log units) above; the measured number falls inside the stated range.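

In this assay, this position can respond: 4-methylphenyl gives the only measured potency among the compounds shown, with an at least 5.8-fold lower number from compound 2 to compound 3 (0.76 log units; beyond the scatter) and, starting from the methyl group, an at least 5.8-fold lower number from compound 1 to compound 3 (0.76 log units; beyond the scatter). Both steps are minimum sizes, because each starting compound gives only a limit: the limit of > 100000 nM in this assay, at which 2 of the 3 values shown sit. Isopropyl therefore shows no readable potency here, while 4-methylphenyl on the same aromatic carbon does.

It remains open whether the gain needs the ring's methyl group, since plain phenyl is not among these compounds. Going by these compounds, the effect of a longer alkyl chain, an amine or a carboxylic acid at this position also remains open.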